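Pyrrolidine to piperidine on the amide side chain

The source may report more compounds than this note shows. Statements on the series, on what has been measured and on what is new or still open speak of the compounds shown alone.

compound 1 `CN1CCN(C23CCN(CCCN4CCCCC4)C(C(c4ccccc4)C2)C(c2ccccc2)C3)CC1` 28900 nM
compound 2 `CN1CCN(C23CC(NC(=O)CN4CCCC4)C(C(c4ccccc4)C2)C(c2ccccc2)C3)CC1` 27800 nM
compound 3 `CCN(CC)CCCN1CCC2(N3CCN(C)CC3)CC(c3ccccc3)C1C(c1ccccc1)C2` 68100 nM

In an ADME assay on L6 cells (Rattus norvegicus) for cytotoxicity, read by fluorescence, with a stated time of 72 h (a lower number here means a stronger inhibitor, a higher number a weaker inhibitor), compound 2 (27800 nM) and compound 1 (28900 nM) lie within the scatter of each other. Compound 3 (68100 nM) shows the highest number of the set, so compound 2 sits at the lower, level pair.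

Compound 4 `CN1CCN(C23CC(NC(=O)CN4CCCCC4)C(C(c4ccccc4)C2)C(c2ccccc2)C3)CC1` differs from compound 2 in one place, with piperidin-1-yl in place of pyrrolidin-1-yl on a saturated chain carbon bound to a carbonyl carbon.

Going by the values given here, no measured step covers this exchange. Among the compounds with values here, the only step available is modest (a 2.4-fold higher number from compound 1 to compound 3 (0.37 log units; beyond the scatter)), and it bears only loosely, since it puts diethylamino in place of piperidin-1-yl on a saturated chain carbon, three bonds along the chain from an amine nitrogen in a ring. The whole set spans a narrow range in this assay, and compound 1, which also carries piperidin-1-yl, gives 28900 nM without leaving the scatter of compound 2. A step beyond the scatter is therefore not expected, and no direction is favoured.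

The expected change is small (a 1.0-fold lower number from compound 2 to compound 4 (0.01 log units; within the scatter)). Compound 4 is estimated at 27000 nM, with an expected range from 14000 nM to 52000 nM.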

Compound 4, half-maximal inhibitory concentration: 22100 nM
Compound 4: the middle estimate sits 1.2-fold (0.09 log units) above what was measured; the measured number falls inside the stated range.
By their numbers in this assay, from the lowest: compounds 4, 2 and 1 (each within the scatter of the next); then compound 3.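

In this assay, the exchange of pyrrolidin-1-yl for piperidin-1-yl on a saturated chain carbon bound to a carbonyl carbon gives a 1.3-fold lower number from compound 2 to compound 4 (0.10 log units; within the scatter) and so stays within the scatter. Going by these compounds alone, this is the first measured step at this position, and it shows that a six-membered non-aromatic ring of 6 heavy atoms can stand in place of a five-membered one of 5 heavy atoms with no readable shift in this read-out. No measurement of any property of these compounds accompanies the result, so the flat step remains an observation with nothing to explain it.

The compounds shown hold only these two saturated rings at this position, so it remains open whether a morpholine, a piperazine or an open dimethylamino group would also stay level in this assay. Also open, as far as these compounds go, are a longer chain in place of the single saturated chain carbon bound to the carbonyl carbon and a carboxylic acid on the piperidin-1-yl ring, either of which would test how far this tolerance extends.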